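The source may report more compounds than this note shows. Statements on the series, on what has been measured and on what is new or still open speak of the compounds shown alone.

Measured compounds:
compound 1 `CCCOc1ccc(NC(=O)CCCCCCCSc2nnc(Cc3nn(C)c(=O)c4ccccc34)n2C)cc1` — 40000 nM
compound 2 `Cn1c(Cc2nn(C)c(=O)c3ccccc23)nnc1SCC(=O)Nc1ccc(Cl)cc1Cl` — 9110000 nM

Of the compounds shown here, two of a shared core have been measured in an assay on cells for inhibition of IL15-IL15 receptor (Homo sapiens), read by AlphaScreen, with stated times of 30 min and 1 h; on this read-out higher numbers stand for weaker inhibition and lower numbers for stronger inhibition. Compound 1 gives 40000 nM and stands lowest of the two numbers; its nearest neighbour, compound 2, gives a far higher number, a gap well beyond the usual scatter. For the measured compounds named here, the two differ in more than one place, so no single step between them can be read off.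

Compound 3 `Cn1c(Cc2nn(C)c(=O)c3ccccc23)nnc1SCCCCCCCC(=O)Nc1ccc(Br)cc1Br` has not yet been measured. It differs from compound 1 in one place: 2,4-dibromophenyl in place of 4-propoxyphenyl on an amide-type nitrogen. Going by the values given here, no measured pair isolates this change, so the expectation rests on compound 1 alone, with compound 2 giving only a loose hint that a dihalophenyl group here can go with a high number. The estimate is a modest step toward weaker inhibition, a 2.0-fold higher number from compound 1 to compound 3 (0.30 log units; within the scatter), though none beyond the scatter would not surprise. Compound 3 is expected to give 80000 nM, within 20000 nM to 400000 nM.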

Compound 3, half-maximal inhibitory concentration: 92000 nM
The estimate for compound 3 lay 1.2-fold (0.06 log units) below the measured number; measured number inside the range.
By their numbers in this assay, from the lowest: compound 1; then compound 3; then compound 2.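

In this assay, the amide-type nitrogen now has its first one-place comparison: 2,4-dibromophenyl in place of 4-propoxyphenyl gives a 2.3-fold higher number from compound 1 to compound 3 (0.36 log units; beyond the scatter). The step is modest but lies beyond the usual scatter, so the group on this nitrogen does register in the read-out, with 4-propoxyphenyl giving the stronger inhibition of the two.

Steps involving compound 2 cannot be read, as it differs from compound 1 and compound 3 in more than one place, which leaves the part played by the chain open. Also open, from the compounds shown here alone, is how this position would respond to a single bromine, a butoxy group, an amine or a carboxylic acid on the phenyl ring. No measurement shown here offers an explanation for the step.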